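A few compounds are considered here, and "the series" means these few. Any claim that something is new, unique, unknown or untested is made for them only; others in the source may bear on it.

Compound 1 `COc1ccc(NC(=O)/C=C/c2coc3cc(OC)ccc3c2=O)cc1`: 13000 nM
Compound 2 `COc1ccc2c(=O)c(/C=C/C(=O)Nc3ccccc3C)coc2c1`: 7270 nM

Within the data shown here, in a functional assay on HeLa cells (Homo sapiens) for inhibition, read by MTT assay, with a stated time of 48 h (on this read-out lower numbers stand for stronger inhibition and higher numbers for weaker inhibition), compound 2 stands within the scatter of compound 1, the only other compound measured so far, so the two cannot be told apart on these numbers. The next compound is compound 3 `COc1ccc2c(=O)c(/C=C/C(=O)NCc3ccc(F)cc3F)coc2c1`, where 2,4-difluorobenzyl takes the place of 2-methylphenyl on an amide-type nitrogen: 2,4-difluorobenzyl in place of 2-methylphenyl on an amide-type nitrogen. Among the measured compounds shown here, the only measured step sits on that same amide-type nitrogen and is small, a 1.8-fold lower number from compound 1 to compound 2 (0.25 log units; within the scatter), so no step beyond the scatter is expected in this assay, in either direction. For the measured compounds named here, no measured compound carries a 2,4-difluorobenzyl group, so this expectation remains loose. The expected change is a 1.2-fold higher number from compound 2 to compound 3 (0.09 log units; within the scatter). For compound 3 the estimated value is 9000 nM, with an expected range of 3000 nM to 27000 nM.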

Compound 3, half-maximal inhibitory concentration: > 100000 nM
Compound 3 ended at the assay's limit (the forecaster's own chance of this, stated with the estimate: 10%); middle value at least 11-fold (1.04 log units) from the limit.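

In this assay, the amide-type nitrogen proves sensitive to what it carries, which the earlier step, within the scatter, did not show: the change to 2,4-difluorobenzyl gives an at least 13-fold higher number from compound 2 to compound 3 (1.13 log units; beyond the scatter), and set against 4-methoxyphenyl it gives an at least 7.6-fold higher number from compound 1 to compound 3 (0.88 log units; beyond the scatter). Both steps are beyond the scatter, so the two aryl amides and the 2,4-difluorobenzyl amide can be told apart here. The value of compound 3 is a limit and not a number, so the true size of both steps stays unknown: the limit of > 100000 nM in this assay, at which 1 of the 3 values shown sits.

The change brings in fluorine and also replaces a phenyl group with a benzyl group, and the compounds shown do not separate these two features. On these data alone, whether a plain benzyl, a fluorophenyl or a longer chain ending in an amine would be tolerated on that nitrogen remains open.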